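From chloro to amino on a 2-phenylethenyl compound

The compounds below may be only part of what the source reports. "The series", "measured", "known", "first", "only" and "open" are said of these compounds alone.

Compound 1 (`Clc1nc(C#Cc2ccccc2)c2ncn(Cc3ccccc3)c2n1`) gives 0.8 ug/mL
Compound 2 (`Clc1nc(/C=C/c2ccccc2)c2ncn(Cc3ccccc3)c2n1`) gives 6 ug/mL

In a functional assay on K562 cells (Homo sapiens) for inhibition, read by thymidine incorporation, with a stated time of 5 h (on this read-out higher numbers stand for weaker inhibition and lower numbers for stronger inhibition), compound 2 has the higher of the two numbers. For the measured compounds named here, the only measured step, a 7.5-fold higher number from compound 1 to compound 2 (0.88 log units; beyond the scatter), is 2-phenylethenyl in place of 2-phenylethynyl on an aromatic carbon. Compound 3 (`Nc1nc(/C=C/c2ccccc2)c2ncn(Cc3ccccc3)c2n1`) changes another group: amino in place of chloro on an aromatic carbon. Going by the values given here, no measured step covers this replacement, so that step offers only a rough scale, and the direction is a tentative expectation. The expected change, towards weaker inhibition, is a 2.3-fold higher number from compound 2 to compound 3 (0.37 log units; beyond the scatter), a modest step. For compound 3 the estimated value is 14 ug/mL (range 3 ug/mL to 60 ug/mL).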

Compound 3, half-maximal inhibitory concentration: 2 ug/mL
Compound 3: the middle estimate sits 7.0-fold (0.85 log units) above what was measured; the whole stated range lies above it.
By their numbers in this assay, from the lowest: compound 1; then compound 3; then compound 2.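

In this assay, the earlier step concerned only the 2-phenylethenyl group, whereas this one shows that the aromatic carbon between two ring nitrogen atoms also affects the read-out. Amino in place of chloro gives a 3.0-fold lower number from compound 2 to compound 3 (0.48 log units; beyond the scatter) and so moves towards stronger inhibition, which shows that chloro is not needed there for inhibition on this 2-phenylethenyl compound. No measurement available here accounts for the change.

The compounds shown leave open whether amino in place of chloro would act likewise on compound 1. They also leave open how methylamino, dimethylamino or hydroxyl would fare on this carbon.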